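A few compounds are considered here, and "the series" means these few. Any claim that something is new, unique, unknown or untested is made for them only; others in the source may bear on it.

Compound 1 `CSc1nc(Br)c(C(=O)c2ccccc2)s1` and compound 2 `O=C(c1ccccc1)c1sc(N2CCCC2)nc1Br` share one core and differ by pyrrolidin-1-yl in place of methylsulfanyl on an aromatic carbon. In a functional assay on SK-MEL-28 cells (Homo sapiens) for cytotoxicity, read by MTT assay, with a stated time of 72 h (a higher number here means a weaker inhibitor, a lower number a stronger inhibitor), compound 1 gives only a limit, > 100000 nM. Compound 2 likewise gives only a limit, > 100000 nM. The step that the two limits leave unreadable from compound 1 to compound 2 therefore cannot be read, as the limit of > 100000 nM in this assay, at which 3 of the 3 values shown sit, makes plain. Compound 3 `COC(=O)c1sc2nc(SC)sc2c1C` rests on another core; how its core differs from that of compound 1 is not broken down here. In this assay compound 3 also gives only a limit, > 100000 nM. Compound 4 `COC(=O)c1sc2nc(N3CCCC3)sc2c1C` has not yet been measured and arises from compound 3 by pyrrolidin-1-yl in place of methylsulfanyl on an aromatic carbon. Going by the values given here, this is the same kind of change as the one from compound 1 to compound 2, but the surroundings differ: in compound 3 the aromatic carbon is part of a fused or bridged system of two rings, whereas in compound 1 it lies two ring bonds from the ring atom that bears a bromo group and two ring bonds from the ring atom that bears a group of 8 heavy atoms. Because every value shown sits at the limit of > 100000 nM in this assay, at which 3 of the 3 values shown sit, the expected step in this assay is a step that the limit leaves unreadable from compound 3 to compound 4, and a limit is again the likeliest report. The estimate for compound 4 in this assay is 150000 nM, expected to lie between 40000 nM and 600000 nM.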

Compound 4, half-maximal inhibitory concentration: > 100000 nM
Compound 4 ended at the assay's limit (the forecaster's own chance of this, stated with the estimate: 85%); the middle value is on the limit's open side.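

In this assay compound 4 gives only a limit (> 100000 nM). No step can be read between compound 3 and compound 4, because both end at that limit: (the limit of > 100000 nM in this assay, at which 4 of the 4 values shown sit). The compounds shown leave open whether pyrrolidin-1-yl in place of methylsulfanyl changes cytotoxicity on either core, since no value falls within the readable range.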